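Chloro to Methylamino: What to Expect for Compound 3

A few compounds are considered here, and "the series" means these few. Any claim that something is new, unique, unknown or untested is made for them only; others in the source may bear on it.

Measured so far:
Compound 1 `CC(CCO)n1cnc2c(Cl)ncnc21` in a functional assay on HCT-116 cells (Homo sapiens) for antiproliferative activity, read by MTT assay, with a stated time of 48 h (on this read-out lower numbers stand for stronger inhibition and higher numbers for weaker inhibition), gives > 50000 nM, a limit of the assay.
Compound 2 `CCCCCC(CCO)n1cnc2c(Cl)ncnc21` in this assay gives > 50000 nM, also a limit of the assay.

Both values sit at the limit of > 50000 nM in this assay, at which 2 of the 2 values shown sit, so the step that the two limits leave unreadable from compound 1 to compound 2 cannot be read, and compound 2 stands only at a limit. Compound 3 `CCCCCC(CCO)n1cnc2c(NC)ncnc21` differs by methylamino in place of chloro on an aromatic carbon. No measured step bears on this change; the single step shown is unreadable, so neither size nor direction can be taken from it, and the expectation for compound 3 rests on compound 2 sitting at the limit of > 50000 nM in this assay, at which 2 of the 2 values shown sit. Compound 3 is expected at 40000 nM, ranging from 8000 nM to 100000 nM. That estimate means an expected step of an at least 1.2-fold lower number from compound 2 to compound 3 (0.09 log units; that floor lies within the scatter).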

Compound 3, half-maximal inhibitory concentration: > 50000 nM
Compound 3: only a limit was reported (the forecaster's own chance of this, stated with the estimate: 65%); middle value at least 1.2-fold (0.09 log units) from the limit.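

For the compounds shown here, compound 2 and compound 3 each stand only at a limit, so no step between them can be read: the limit of > 50000 nM in this assay, at which 3 of the 3 values shown sit. The compounds shown leave open whether methylamino in place of chloro changes anything in this assay.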